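Shortening a Polyether Chain and Its Effect on Solubility

A few compounds are considered here, and "the series" means these few. Any claim that something is new, unique, unknown or untested is made for them only; others in the source may bear on it.

The measured compounds, in a physicochemical assay for solubility, in phosphate buffer, at pH 7.4; on this read-out higher numbers stand for higher solubility and lower numbers for lower solubility:
- compound 1, `COCCOCCOCCOCCOCCOCCOC(=O)Oc1c(C(C)C)cccc1C(C)C`, gives 830 ug/mL
- compound 2, `COCCOCCOCCOC(=O)Oc1c(C(C)C)cccc1C(C)C`, gives 190 ug/mL
- compound 3, `COCCOCCOCCOCCOCCOCCOCCOCCOCCOCCOCC(=O)Oc1c(C(C)C)cccc1C(C)C`, gives only a limit of the assay, > 371000 ug/mL

Compound 1 and compound 2 differ in one place: hydrogen in place of (2-(2-methoxyethoxy)ethoxy)methyl on a saturated chain carbon bound to an oxygen on a saturated carbon. This change brings a 4.4-fold lower number from compound 1 to compound 2 (0.64 log units; beyond the scatter).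

Compound 4, `COCCOCCOCCOCCOCCOCCOCCOCC(=O)Oc1c(C(C)C)cccc1C(C)C`, is not yet measured. It is made from compound 3 by the same change, (hydrogen in place of (2-(2-methoxyethoxy)ethoxy)methyl on a saturated chain carbon bound to an oxygen on a saturated carbon), at the same kind of position as in the earlier pair. The difference between the core of compound 1 and the core of compound 3 is not broken down here.

For compound 3 there is no number, only a limit, because of the limit of > 371000 ug/mL in this assay, at which 1 of the 3 values shown sits. This makes the starting point of the new step uncertain: the true value of compound 3 could sit anywhere past the limit.

Going by the earlier pair, the step from compound 3 to compound 4 in this assay is expected to be a drop of a similar size, so that an at least 2.4-fold lower number from compound 3 to compound 4 (0.39 log units; beyond the scatter) is the expected change, resting on the measured step of a 4.4-fold lower number from compound 1 to compound 2 (0.64 log units; beyond the scatter). Since the starting value is itself a limit, compound 4 may well still exceed what the assay can report. As a central expectation, compound 4 is estimated at 150000 ug/mL, with a plausible range from 30000 ug/mL to 400000 ug/mL.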

Compound 4, solubility: > 216000 ug/mL
Compound 4: a limit, no number (the forecaster's own chance of this, stated with the estimate: 40%); at least 1.4-fold (0.15 log units) between middle value and limit.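

In this assay compound 4 gives > 216000 ug/mL, a limit of the assay and not a number. Compound 3 gives > 371000 ug/mL, also a limit. With a limit at both ends, the step from compound 3 to compound 4 cannot be read. The compounds shown leave open how large the true change in this assay is when hydrogen replaces (2-(2-methoxyethoxy)ethoxy)methyl on this chain, and whether it matches the earlier pair.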